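Aromatic substituent swap from compound 3 to compound 4

This account rests on a few compounds, and the source may have more. Where it says the series, first, only, none or still open, it means among the compounds named here.

Of the compounds shown here, three have been read in an ADME assay on HepG2 cells (Homo sapiens) for cytotoxicity, read by CellTiter-Glo and resazurin assay, with a stated time of 72 h (a higher number here means that more compound is needed for the effect, a lower number that less compound is needed), and none gives a number. Compound 1 (`CC(C)N(Cc1cccc(OCCCCCC(=O)O)c1)C(=O)c1ccc(-c2cccc(Oc3ccccc3)c2)cc1`) gives > 18700 nM, which is a limit. Compound 2 (`COc1cccc(-c2ccc(C(=O)N(Cc3cccc(OCCCCCC(=O)O)c3)C(C)C)cc2)c1`) gives > 26000 nM, also a limit. Compound 3 (`CC(C)N(Cc1cccc(OCCCCCC(=O)O)c1)C(=O)c1ccc(-c2ccc3c(c2)OCCO3)cc1`) gives > 21900 nM, again a limit, so it stands with the other two and has no rank among them.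

Compound 4 (`CC(C)N(Cc1cccc(OCCCCCC(=O)O)c1)C(=O)c1ccc(-c2cccc(F)c2)cc1`) is the next to be read. It differs from compound 3 as follows: 3-fluorophenyl in place of 2,3-dihydro-1,4-benzodioxin-6-yl on an aromatic carbon. In short, 3-fluorophenyl stands in place of 2,3-dihydro-1,4-benzodioxin-6-yl on an aromatic carbon, para to a large group.

Two measured changes bear on this. The closer is a step that the two limits leave unreadable from compound 2 to compound 3, a swap on the same aromatic carbon. The other is a step that the two limits leave unreadable from compound 1 to compound 2. Neither has a readable size, so no step beyond the scatter is expected, and another limit is the likely report. The expected move is a step that the limit leaves unreadable from compound 3 to compound 4. For compound 4 the estimate is 25000 nM, with an expected range of 12000 nM to 50000 nM.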

Compound 4, half-maximal effective concentration: > 26000 nM
Compound 4: only a limit was reported; the forecaster's own chance of this, stated with the estimate: 85%; middle value at least 1.0-fold (0.01 log units) from the limit.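

In this assay compound 4 gives > 26000 nM, a limit. Among the compounds shown here, compound 1, compound 2 and compound 3 are also reported only as limits, so no step to compound 4 can be read. The compounds shown leave open whether any swap on this aromatic carbon changes the half-maximal effective concentration in this assay.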